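The compounds below may be only part of what the source reports. "The series", "measured", "known", "first", "only" and "open" are said of these compounds alone.

Working notes on the series. In a functional assay on DU-145 cells (Homo sapiens) for inhibition, read by trypan blue exclusion, with a stated time of 96 h (a lower number here means a stronger inhibitor of growth, a higher number a weaker inhibitor of growth), compound 1 `O=C(O)c1ccc(C(=O)/C(=C\c2ccc(Br)cc2)SCc2ccc(F)cc2)cc1` gives > 100000 nM, which is a limit and not a number. Compound 2 `O=C(/C(=C\c1ccc(O)cc1O)SCc1cccc(Cl)c1)c1ccc(Br)cc1` gives 50000 nM, and compound 3 `COc1ccc(S/C(=C/c2ccc(Cl)cc2Cl)C(=O)c2ccc(Br)cc2)cc1` gives 1000 nM. Compound 4 `O=C(O)c1ccc(C(=O)/C(=C\c2ccc(Cl)c([N+](=O)[O-])c2)SCc2ccc(F)cc2)cc1` differs from compound 1 by 4-chloro-3-nitrophenyl in place of 4-bromophenyl on a double-bonded chain carbon bound to a double-bonded chain carbon, with 4-chloro-3-nitrophenyl in place of 4-bromophenyl and the rest of the structure unchanged. Going by the values given here, no measured step gives the size of this change. With compound 1 resting on (the limit of > 100000 nM in this assay, at which 1 of the 3 values shown sits), the expected step is an at least 1.4-fold lower number from compound 1 to compound 4 (0.15 log units; that floor lies within the scatter), a modest one towards stronger inhibition of growth. For compound 4 the estimated value is 70000 nM, with an expected range of 15000 nM to 200000 nM.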

Compound 4, concentration for 50% growth inhibition: 1000 nM
Estimate against measurement, compound 4: 70-fold (1.85 log units) above, outside the stated range (below it).
By their numbers in this assay, from the lowest: compounds 3 and 4 (each within the scatter of the next); then compound 2. At a limit, above all of these: compound 1.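

In this assay, going by these compounds alone, 4-chloro-3-nitrophenyl in place of 4-bromophenyl on a double-bonded chain carbon bound to a double-bonded chain carbon gives an at least 100-fold lower number from compound 1 to compound 4 (2.00 log units; beyond the scatter), the only step measured, so a change at this place alone can carry a large effect. The size of that step is only a floor, because the value of compound 1 is a limit: the limit of > 100000 nM in this assay, at which 1 of the 4 values shown sits.

On these data alone, the chloro and nitro groups enter together, so which of them carries the step stays open. As far as these compounds go, whether an amine in place of the nitro group would keep it is also open.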